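The source may report more compounds than this note shows. Statements on the series, on what has been measured and on what is new or still open speak of the compounds shown alone.

Measured so far:
compound 1 `CN(C)S(=O)(=O)CCNc1nonc1/C(=N/O)Nc1ccc(F)c(Br)c1`: 17 nM
compound 2 `O=S(=O)(CCNc1nonc1/C(=N/O)Nc1ccc(F)c(Br)c1)N1CCC1`: 143 nM

In an assay on HeLa cells for inhibition of Indoleamine 2,3-dioxygenase 1 (Homo sapiens), read by spectrophotometry, with a stated time of 24 h (a higher number here means that more compound is needed for the effect, a lower number that less compound is needed), compound 2 stands highest of the two numbers, and its nearest neighbour is compound 1 at 17 nM. Compound 3 `CCNS(=O)(=O)CCNc1nonc1/C(=N/O)Nc1ccc(F)c(Br)c1` differs from compound 2 by ethylamino in place of azetidin-1-yl on a sulfonyl sulfur. Going by the values given here, the one step that bears on this, an 8.4-fold higher number from compound 1 to compound 2 (0.92 log units; beyond the scatter), installed the ring that the present change removes, so a step back toward the number of compound 1 is expected for compound 3, though ethylamino is not dimethylamino and a partial reversal is the safer guess, about a 3.2-fold lower number from compound 2 to compound 3 (0.50 log units; beyond the scatter). Compound 3 is therefore estimated at 45 nM, with a range of 12 nM to 160 nM.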

Compound 3, half-maximal effective concentration: 41 nM
For compound 3 the middle estimate is 1.1-fold (0.04 log units) above the measured one; the measured number falls inside the stated range.
By their numbers in this assay, from the lowest: compound 1; then compound 3; then compound 2.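

In this assay, ethylamino in place of azetidin-1-yl on a sulfonyl sulfur gives a 3.5-fold lower number from compound 2 to compound 3 (0.54 log units; beyond the scatter), so this position responds to opening the ring and the number moves back toward that of the dimethylamino compound. The return is only partial: ethylamino in place of dimethylamino gives a 2.4-fold higher number from compound 1 to compound 3 (0.38 log units; beyond the scatter), so two open-chain groups at this position also differ beyond the scatter. No measurement here explains either step.

Still open, going by these compounds, is whether the ring or the hydrogen on the ethylamino nitrogen drives these differences. A methylamino, diethylamino or pyrrolidin-1-yl group on the same sulfur would test this.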